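The source may report more compounds than this note shows. Statements on the series, on what has been measured and on what is new or still open speak of the compounds shown alone.

Measured so far in a functional assay on PC-3 cells (Homo sapiens) for inhibition, read by sulforhodamine B assay, with a stated time of 48 h; a lower number here means a stronger inhibitor of growth, a higher number a weaker inhibitor of growth:
compound 1 `Nc1cc(N)c2nc(-c3ccccc3)c(Oc3ccc(Cl)c(Cl)c3)nc2c1`: 3020 nM
compound 3 `Nc1cc(N)c2nc(-c3ccccc3)c(NCc3ccc(Cl)c(Cl)c3)nc2c1`: 1740 nM
Compound 2 `CCOC(=O)[C@H](CCC(=O)O)NC(=O)c1ccc(CNc2nc3cc(N)cc(N)c3nc2-c2ccccc2)cc1` returns only a limit, < 100000 nM, in this assay.

Compound 3 thus holds the lower of the two numbers, but its gap to compound 1 is within the scatter, so the two cannot be told apart. Compound 4 `COc1ccc(CNc2nc3cc(N)cc(N)c3nc2-c2ccccc2)cc1` is not yet measured; it differs from compound 3 by 4-methoxyphenyl in place of 3,4-dichlorophenyl on a saturated chain carbon bound to a nitrogen on an aromatic ring. For the measured compounds named here, no measured pair of compounds shows what such a change does here. With no guide, the step from compound 3 to compound 4 is expected to be small in this assay, perhaps towards a weaker inhibitor, as a 1.7-fold higher number from compound 3 to compound 4 (0.24 log units; within the scatter). Compound 4 is therefore estimated at 3000 nM, within a range of 800 nM to 12000 nM.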

Compound 4, concentration for 50% growth inhibition: 10200 nM
Compound 4: the middle estimate sits 3.4-fold (0.53 log units) below what was measured; the range from low to high includes it.
By their numbers in this assay, from the lowest: compounds 3 and 1 (each within the scatter of the next); then compound 4.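

In this assay, 4-methoxyphenyl in place of 3,4-dichlorophenyl on a saturated chain carbon bound to a nitrogen on an aromatic ring gives a 5.9-fold higher number from compound 3 to compound 4 (0.77 log units; beyond the scatter). For the compounds shown here, this is the first step between compounds differing in one place, and it shows that the number responds to the group carried here. Nothing given here accounts for the size of this step.

The compounds shown do not separate the departure of the two chlorines from the arrival of the methoxy group. Going by these compounds, how a plain phenyl, a 4-chlorophenyl or a carboxylic acid on the ring would fare at this place remains open.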